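The compounds below may be only part of what the source reports. "The series", "measured", "known", "first", "only" and "open" are said of these compounds alone.

Measured so far:
- compound 1 `O=C(NC(=S)Nc1ccccc1)c1ccccc1F`: in an assay on isolated protein for inhibition of protein deacetylase HDAC6 (Homo sapiens), read by fluorescence, tested at 100 uM (a higher number here means more inhibition at the concentration tested (going by the name of the read-out), a lower number less inhibition), compound 1 gives "not active" (no number reported)
- compound 2 `O=C(NC(=S)Nc1ccccc1)c1ccccc1`: in this assay compound 2 gives 30%
- compound 3 `O=C(NC(=S)NCc1cccs1)c1ccccc1`: not yet measured

Compound 1 is recorded in this assay only as not active, with no number attached, so compound 2 holds the only numeric result in the set; the two share a common core, compound 1 carrying a fluorine on one of its rings, but without a number for compound 1 nothing can be said about the size of the gap between them.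

Compound 3 differs from compound 2 in a single place: (thiophen-2-yl)methyl in place of phenyl on an amide-type nitrogen. Going by the values given here, with only one number available, no measured step can guide the expectation. The account therefore expects compound 3 to sit near compound 2, with the change from compound 2 to compound 3 estimated at a number 8 percentage points lower from compound 2 to compound 3 (within the scatter), a step not beyond the usual scatter, tending if anything toward less inhibition. Compound 3 is thus estimated at 22% in this assay, with a range from 0% to 45%.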

Compound 3, a percentage reported as inhibition, at one concentration (the size of the read-out at that concentration, not a potency): 10%
Estimate against measurement, compound 3: 12 percentage points above, and the stated range covers the measured number.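

In this assay, placing (thiophen-2-yl)methyl instead of phenyl on the amide-type nitrogen whose other neighbour is the thiocarbonyl carbon gives a number 20 percentage points lower from compound 2 to compound 3 (beyond the scatter). Going by these compounds alone, this is the first readable step in the set, as compound 1 has no number to compare, and it shows that the read-out at this position depends on which group the nitrogen carries. The swap changes a six-membered aromatic ring of carbon only to a five-membered aromatic ring with one hetero atom and also brings in the methyl link, and nothing measured here bears on why the number falls with this change.

The compounds shown do not separate the ring from the link, a question that benzyl or thiophen-2-yl on the same nitrogen could address. They also leave open how this nitrogen would respond to a longer chain ending in thiophene, or to a group carrying an amine or a carboxylic acid.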